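Quinolin-7-yl sulfonamide as successor to the oxazole analogue

The compounds below may be only part of what the source reports. "The series", "measured", "known", "first", "only" and "open" are said of these compounds alone.

The series shares a piperidine amide core, shown for compound 1 as `CCN(Cc1ccccc1)C(=O)C1CCN(S(=O)(=O)c2ccccc2OC)CC1`, for compound 2 as `CCN(Cc1ccccc1)C(=O)C1CCN(S(=O)(=O)c2ccc(OC)c(OC)c2)CC1` and for compound 3 as `CCN(Cc1ccccc1)C(=O)C1CCN(S(=O)(=O)c2c(C)noc2C)CC1`. In a functional assay on CHO cells for positive allosteric modulation of muscarinic acetylcholine receptor M5 (Homo sapiens), read by calcium flux (a lower number here means a smaller maximal response, a higher number a larger maximal response), compound 2 reaches 57%, while compound 1 shows "not determined" (no result reported) and compound 3 shows "not determined" (no result reported), so compound 3 has no number to stand on, and compound 1 is in the same position. Compound 4, `CCN(Cc1ccccc1)C(=O)C1CCN(S(=O)(=O)c2ccc3cccnc3c2)CC1`, differs from compound 3 by quinolin-7-yl in place of 3,5-dimethyl-1,2-oxazol-4-yl on a sulfonyl sulfur. Going by the values given here, no measured step in this assay connects these two compounds, so the direction of the change is open; a shift beyond the scatter in either direction is possible. Compound 4 is expected to give about 55%, within 20% to 95%.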

Compound 4, largest response reached (reported as percent of maximum), in percent of the reference or control that the assay uses: 66%
Compound 4: middle estimate off by 11 percentage points, on the low side; measured number inside the range.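

In this assay the change gives a number 9 percentage points higher from compound 2 to compound 4 (within the scatter), so quinolin-7-yl and 3,4-dimethoxyphenyl on a sulfonyl sulfur cannot be told apart in this read-out. Going by these compounds alone, as the only readable step at this position, it shows that a clear maximal response is kept with two six-membered aromatic rings in this place. No supporting measurement speaks to what lies behind this.

Compound 1 and compound 3 carry no number, so the steps to them cannot be read. On these data alone, whether an amine or a carboxylic acid on the quinolin-7-yl group would keep this response remains open.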